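From piperidinyl to fluoroanilino on a shared core

The source may hold more compounds than are shown below. What is called first, only, known or untested is meant among the compounds shown, and "the series" means these compounds.

Compound 1 `FC(F)(F)c1ccc(CSc2nc(N3CCCCC3)c3ccccc3n2)cc1` was tested in a functional assay on HGC-27 cells (Homo sapiens) for cytotoxicity, read by MTT assay, with a stated time of 72 h; a higher number here means a weaker inhibitor, a lower number a stronger inhibitor. There compound 1 gives > 50000 nM, which is a limit of the assay rather than a measured number. Swapping the piperidin-1-yl group gives compound 2 `FC(F)(F)c1ccc(CSc2nc(Nc3ccccc3)c3ccccc3n2)cc1`, which gives 26400 nM, and compound 3 `FC(F)(F)c1ccc(CSc2nc(Nc3cccc(Cl)c3)c3ccccc3n2)cc1`, which gives 19900 nM. Both changes lower the number: an at least 1.8-fold lower number from compound 1 to compound 2 (0.27 log units; that floor lies within the scatter), and an at least 2.5-fold lower number from compound 1 to compound 3 (0.40 log units; beyond the scatter); between the two anilines a 1.3-fold lower number from compound 2 to compound 3 (0.12 log units; within the scatter). Each of these steps rests on the limit of compound 1 (the limit of > 50000 nM in this assay, at which 1 of the 3 values shown sits), so only its minimum size is known. Compound 4 `Fc1ccc(Nc2nc(SCc3ccc(C(F)(F)F)cc3)nc3ccccc23)cc1` carries the change ((4-fluorophenyl)amino in place of piperidin-1-yl on an aromatic carbon). On the strength of compound 2 and compound 3, compound 4 is expected to show an at least 2.2-fold lower number from compound 1 to compound 4 (0.35 log units; beyond the scatter). The estimated value of compound 4 in this assay is 22000 nM, within 10000 nM to 45000 nM.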

Compound 4, half-maximal inhibitory concentration: 19500 nM
The estimate for compound 4 lay 1.1-fold (0.05 log units) above the measured number; low and high end bracket the measured number.
By their numbers in this assay, from the lowest: compounds 4, 3 and 2 (each within the scatter of the next). At a limit, above all of these: compound 1.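

With (4-fluorophenyl)amino on the shared core, this assay shows (an at least 2.5-fold lower number from compound 1 to compound 4 (0.40 log units; beyond the scatter)), a minimum size only, because compound 1 stands at a limit: the limit of > 50000 nM in this assay, at which 1 of the 4 values shown sits. Adding fluoro to the aniline ring leaves the number within the scatter (a 1.4-fold lower number from compound 2 to compound 4 (0.13 log units; within the scatter)), and so does 4-fluorophenyl in place of 3-chlorophenyl (a 1.0-fold lower number from compound 3 to compound 4 (0.01 log units; within the scatter)), so neither halogen separates these three anilines. As far as these compounds go, whether a methoxy or a nitrile on the aniline ring would move the number beyond the scatter stays open.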